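Replacing the (Carboxymethyl)carbamoyl Arm with 3-Carboxypropyl

A few compounds are considered here, and "the series" means these few. Any claim that something is new, unique, unknown or untested is made for them only; others in the source may bear on it.

Compound 1 `O=C(O)CNC(=O)COc1ccc([C@H]2CC[C@]3(CC2)OOC2(O3)C3CC4CC(C3)CC2C4)cc1` stands second highest of three in a physicochemical assay for lipophilicity, read by HPLC, at pH 7.4 (on this read-out lower numbers stand for lower lipophilicity and higher numbers for higher lipophilicity), giving 3. Its nearest neighbour is compound 3 `O=C(O)COc1ccc([C@H]2CC[C@]3(CC2)OOC2(O3)C3CC4CC(C3)CC2C4)cc1Cl`, which gives 3.2, within the scatter, whereas compound 2 `O=C(O)COc1ccc([C@H]2CC[C@]3(CC2)OOC2(O3)C3CC4CC(C3)CC2C4)cc1C(=O)O` gives 1.9, a gap beyond the scatter. Going by the values given here, the only measured single-point step, a number 1.30 log units higher from compound 2 to compound 3 (beyond the scatter), concerns a substituent on the aromatic ring and leaves the acid-bearing chain untouched. Compound 4 `O=C(O)CCCCOc1ccc([C@H]2CC[C@]3(CC2)OOC2(O3)C3CC4CC(C3)CC2C4)cc1` differs from compound 1 by 3-carboxypropyl in place of (carboxymethyl)carbamoyl on a saturated chain carbon bound to an oxygen on an aromatic ring. Among the compounds with values here, no measured step bears directly on this exchange, so the expectation can rest only on the groups that leave and enter. Compound 4 is therefore expected to move by a number 0.80 log units higher from compound 1 to compound 4 (beyond the scatter), to an estimated 3.8, within a range of 3.2 to 4.4.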

Compound 4, distribution coefficient: 4
Beside the measured number, compound 4's estimate is 0.20 log units below it, and the stated range covers the measured number.
By their numbers in this assay, from the lowest: compound 2; then compounds 1 and 3 (each within the scatter of the next); then compound 4.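

In this assay, exchanging (carboxymethyl)carbamoyl for 3-carboxypropyl on a saturated chain carbon bound to an oxygen on an aromatic ring gives a number 1.00 log units higher from compound 1 to compound 4 (beyond the scatter), showing that the read-out responds beyond the scatter to a change at this position, not only to one on the aromatic ring. The exchange keeps a carboxy group and removes the carbamoyl link. No measurement shown accounts for the size of this step. The compounds shown leave open how a shorter or longer carboxyalkyl chain would read, and whether an amine in place of the carboxylic acid would move the number in the same direction.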